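Aryl swap on a shared core: what compound 3 may give

The source may report more compounds than this note shows. Statements on the series, on what has been measured and on what is new or still open speak of the compounds shown alone.

compound 1 `Cc1ccc(-c2noc(C3CCc4c(nnn4C(C)(C)C)C3)n2)cn1` — 67%
compound 2 `CC(C)(C)n1nnc2c1CCC(c1nc(Cc3ccc(F)cc3)no1)C2` — 77%

Within the data shown here, in a functional assay on U2OS cells with metabotropic glutamate receptor 5 (Homo sapiens) as the target, read by calcium flux (a lower number here means a smaller maximal response, a higher number a larger maximal response), compound 2 stands within the scatter of compound 1, the only other measured compound, as a number 10 percentage points higher from compound 1 to compound 2 (within the scatter) shows. Compound 3 `CC(C)(C)n1nnc2c1CCC(c1nc(-c3ccc(C#N)cc3)no1)C2` differs from compound 2 by 4-cyanophenyl in place of 4-fluorobenzyl on an aromatic carbon. A single measured step bears on this exchange: the same place was varied once before, and that step, a number 10 percentage points higher from compound 1 to compound 2 (within the scatter), remained within the scatter. A step of comparable size is therefore expected, none beyond the scatter, estimated as a number 5 percentage points lower from compound 2 to compound 3 (within the scatter). Compound 3 is expected at 72%, between 52% and 92%.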

Compound 3, largest response reached (reported as percent of maximum), in percent of the reference or control that the assay uses: 87%
Compound 3: middle estimate off by 15 percentage points, on the low side; the range from low to high includes it.
By their numbers in this assay, from the lowest: compounds 1, 2 and 3 (each within the scatter of the next, the first and the last beyond it).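

In this assay this position now shows a step that clears the scatter: 4-cyanophenyl in place of 6-methylpyridin-3-yl gives a number 20 percentage points higher from compound 1 to compound 3 (beyond the scatter) on the shared core. By contrast, 4-cyanophenyl in place of 4-fluorobenzyl gives a number 10 percentage points higher from compound 2 to compound 3 (within the scatter) and so, like the earlier exchange, does not clear it. Only compound 1 and compound 3 separate, while compound 2 lies within the scatter of both. No evidence at hand speaks to why the larger step arises.

The compounds shown leave open what an amine, a carboxylic acid or a longer chain on this aromatic carbon would give.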